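The source may hold more compounds than are shown below. What is called first, only, known or untested is meant among the compounds shown, and "the series" means these compounds.

Of the compounds shown here, three sharing one core have been measured in a physicochemical assay for lipophilicity, read by HPLC, with a stated time of 90 min, tested at 100 uM; a lower number here means a more polar compound, a higher number a more lipophilic compound. Compound 1 `O=C(Nc1ccc(OC(F)(F)F)c(F)c1)NC1CCN(C(=O)C2CC2)CC1` gives 4.19, the highest of the three numbers. Compound 2 `O=C(Nc1ccc(C(F)(F)F)c(F)c1)NC1CCN(C(=O)C2CC2)CC1` gives 3.94; the step of a number 0.25 log units lower from compound 1 to compound 2 (within the scatter) goes with trifluoromethyl in place of trifluoromethoxy on an aromatic carbon. Compound 3 `O=C(Nc1ccc(OC(F)(F)F)cc1)NC1CCN(C(=O)c2cc[nH]c2)CC1` gives 3.34, a number that lies further from compound 1 than that of compound 2 does, but compound 3 differs from compound 1 in more than one place, so no single change can be tied to that gap.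

Compound 4 `O=C(Nc1ccc(OC(F)(F)F)c(F)c1)NC1CCN(C(=O)[C@@H]2CCOC2)CC1` has not yet been measured. It differs from compound 1 in one place: oxolan-3-yl in place of cyclopropyl on a carbonyl carbon. Within the data shown here, none of the measured steps touches this part of the molecule; the one measured single step concerns the aromatic ring and stays within the scatter, so it offers no guide to the size here. What the counted difference shows is that an oxolan-3-yl group carrying a hydrogen-bond acceptor enters where a cyclopropyl of carbon only leaves. On that basis alone, the expected step of a number 0.69 log units lower from compound 1 to compound 4 (beyond the scatter) points to a lower number, beyond the scatter. Compound 4 is therefore estimated at 3.5, with a range from 3.1 to 3.9.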

Compound 4, partition coefficient: 3.59
For compound 4 the middle estimate is 0.09 log units below the measured one; low and high end bracket the measured number.
By their numbers in this assay, from the lowest: compounds 3 and 4 (each within the scatter of the next); then compounds 2 and 1 (each within the scatter of the next).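

This position, on a carbonyl carbon whose other neighbours are amide-type nitrogen in a ring, had no measured single change until now; in this assay the swap of cyclopropyl for oxolan-3-yl goes with a number 0.60 log units lower from compound 1 to compound 4 (beyond the scatter) at this site. Among the compounds that differ in one place, this is the only step beyond the scatter, whereas the aromatic change gave a number 0.25 log units lower from compound 1 to compound 2 (within the scatter) and stayed within it. Several things change together in this one swap, as oxolan-3-yl brings a larger ring, a ring oxygen that counts as a hydrogen-bond acceptor and a defined stereocentre, and no measurement here explains the step or assigns it to any one of these.

On these data alone, whether the ring oxygen or the larger ring goes with the step remains open, and cyclopentyl, a five-membered ring of carbon only, would separate the two. Also open, as far as these compounds go, are how the other stereoisomer of the oxolan-3-yl compound would read, and how an amine in the same ring, such as pyrrolidin-3-yl, would compare at this carbonyl carbon.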